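Pyridin-2-yl Amide Expected to Move Back Toward Inactivity

The compounds below may be only part of what the source reports. "The series", "measured", "known", "first", "only" and "open" are said of these compounds alone.

Compound 1, `COc1ccc2nc(C)cc(OCC(=O)NCc3cc(C)cc(C)c3)c2c1`: > 100000 nM
Compound 2, `COc1ccc2nc(C)cc(OCC(=O)Nc3c(C)cccc3C)c2c1`: > 100000 nM
Compound 3, `COc1ccc2nc(C)cc(OCC(=O)Nc3ccc(Br)c(C)c3)c2c1`: 15900 nM

In a toxicity assay on HepG2 cells (Homo sapiens) for inhibition, read by CellTiter-Glo, with a stated time of 48 h (on this read-out higher numbers stand for weaker inhibition and lower numbers for stronger inhibition), compound 1 reaches only a limit of the assay, > 100000 nM. Compound 2 likewise reaches only a limit, > 100000 nM. For the measured compounds named here, compound 3 is the sole compound with a readable number, 15900 nM, and therefore stands alone among the three measured compounds. The steps of an at least 6.2-fold lower number from compound 1 to compound 3 (0.79 log units; beyond the scatter) and an at least 6.2-fold lower number from compound 2 to compound 3 (0.79 log units; beyond the scatter) both run out of the limit (the limit of > 100000 nM in this assay, at which 2 of the 3 values shown sit), so their true size cannot be fixed, and a step that the two limits leave unreadable from compound 1 to compound 2 is unreadable for the same reason.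

Compound 4, `COc1ccc2nc(C)cc(OCC(=O)Nc3ccccn3)c2c1`, carries pyridin-2-yl in place of 4-bromo-3-methylphenyl on an amide-type nitrogen. Going by the values given here, no measured step makes a change of this kind; the two steps that bear on it, an at least 6.2-fold lower number from compound 1 to compound 3 (0.79 log units; beyond the scatter) and an at least 6.2-fold lower number from compound 2 to compound 3 (0.79 log units; beyond the scatter), both introduce the 4-bromo-3-methylphenyl group that compound 4 loses. Taking that group away again is expected to undo at least part of the lowering, so an upward step a 5.0-fold higher number from compound 3 to compound 4 (0.70 log units; beyond the scatter) is expected. Compound 4 is estimated at 80000 nM, within a range from 20000 nM to 300000 nM, with a fair chance that only a limit is reported.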

Compound 4, half-maximal inhibitory concentration: > 100000 nM
Compound 4: only a limit was reported (the forecaster's own chance of this, stated with the estimate: 55%); middle value at least 1.2-fold (0.09 log units) away from the limit.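

In this assay compound 4 gives > 100000 nM, which is a limit of the assay and not a number. For the compounds shown here, with pyridin-2-yl in place of 4-bromo-3-methylphenyl on the amide-type nitrogen, the data show an at least 6.2-fold higher number from compound 3 to compound 4 (0.79 log units; beyond the scatter), so compound 3 remains the only one of the four compounds with a readable number, now against an aromatic ring with a hetero atom as well as the two carbon-only groups. The steps from compound 1 and from compound 2 to compound 4 cannot be read, and the limit now holds most of the series: the limit of > 100000 nM in this assay, at which 3 of the 4 values shown sit.

The compounds shown leave open which part of the 4-bromo-3-methylphenyl group goes with the lower number, the bromine or the methyl, and whether a 4-chlorophenyl group on the same nitrogen would also give a readable value. Going by these compounds, the true values of compound 1, compound 2 and compound 4 beyond their limit also remain open.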